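Acid analogue with 4-methoxyphenyl in place of 2,4-difluorophenyl

The compounds below may be only part of what the source reports. "The series", "measured", "known", "first", "only" and "open" are said of these compounds alone.

Measured so far:
compound 1 `CCOC(=O)C1=Cc2ccccc2OC1(OCc1cc(-c2ccc(F)cc2F)no1)C(F)(F)F` — > 150000 nM
compound 2 `CCOC(=O)C1=Cc2ccccc2OC1(OCc1cc(-c2ccc(OC)cc2)no1)C(F)(F)F` — > 150000 nM
compound 3 `O=C(O)C1=Cc2ccccc2OC1(OCc1cc(-c2ccc(F)cc2F)no1)C(F)(F)F` — > 150000 nM

In a functional assay on A549 cells (Homo sapiens) for inhibition, read by MTT assay, with a stated time of 24 h (on this read-out lower numbers stand for stronger inhibition and higher numbers for weaker inhibition), compound 1 gives > 150000 nM, a limit of the assay and not a number. Compound 2 likewise returns a limit, > 150000 nM. Compound 3 also sits at a limit, > 150000 nM. Compound 3 therefore stands where every value shown stands, at the limit of > 150000 nM in this assay, at which 3 of the 3 values shown sit, with no readable number anywhere in the series. The step that the two limits leave unreadable from compound 1 to compound 3 is unreadable for the same reason.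

Compound 4 `COc1ccc(-c2cc(COC3(C(F)(F)F)Oc4ccccc4C=C3C(=O)O)on2)cc1` differs from compound 3 by 4-methoxyphenyl in place of 2,4-difluorophenyl on an aromatic carbon. The same exchange on the ethyl ester, a step that the two limits leave unreadable from compound 1 to compound 2, is also unreadable. Among the compounds with values here, no measured step gives a size for this change, so nothing points to a readable number for compound 4 in this assay.

In this assay compound 4 is expected to give 150000 nM, with a range of 40000 nM to 300000 nM. The expected step of a number no higher from compound 3 to compound 4 (the limit leaves the size open) is an estimate only, and a further limit is the most probable outcome.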

Compound 4, half-maximal inhibitory concentration: 36200 nM
Compound 4: middle estimate off by 4.1-fold (0.62 log units), on the high side, and the stated range ends above it.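

In this assay, 4-methoxyphenyl in place of 2,4-difluorophenyl on the acid gives an at least 4.1-fold lower number from compound 3 to compound 4 (0.61 log units; beyond the scatter). With 4-methoxyphenyl kept, hydrogen in place of ethyl on the oxygen next to the carbonyl group gives an at least 4.1-fold lower number from compound 2 to compound 4 (0.61 log units; beyond the scatter), so in these compounds a readable number appears only with the two features together. The steps among the other compounds cannot be read: the limit of > 150000 nM in this assay, at which 3 of the 4 values shown sit.

On these data alone, whether a single fluorine or a methyl group on the phenyl ring would also give a readable number remains open. So does whether a primary amide could replace the carboxylic acid.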